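Oxygen-to-sulfur swap in the five-membered ring of compound 2

The compounds below may be only part of what the source reports. "The series", "measured", "known", "first", "only" and "open" are said of these compounds alone.

Compound 1 `O=S(=O)(CC1=NCCS1)C1=NNCC1c1ccccc1` gave "not active" (no number reported) in a functional assay, tested at 75 ug/mL (a lower number here means a weaker effect, a higher number a stronger effect of the compound at the concentration tested), so it supplies no number for comparison. Within the data shown here, compound 2 `O=S(=O)(CC1=NCCO1)C1C(c2ccccc2)=NOC1c1ccccc1` is therefore the only compound of the series with a value in this assay, where compound 2 reaches 53.3%; nothing else in the set can be ranked against it. Compound 3 `O=S(=O)(CC1=NCCS1)C1C(c2ccccc2)=NOC1c1ccccc1` is not yet measured. It differs from compound 2 in one place: a group of 5 heavy atoms (3 carbon, 1 nitrogen, 1 sulfur; one five-membered non-aromatic ring with 2 hetero atoms) in place of a group of 5 heavy atoms (3 carbon, 1 nitrogen, 1 oxygen; one five-membered non-aromatic ring with 2 hetero atoms), on a saturated chain carbon bound to a sulfonyl sulfur. Among the measured compounds shown here, compound 1 carries the same entering group on a different shared core, and its result in this assay was not quantified, so it gives no scale for the step. For the measured compounds named here, no measured pair with this single change exists, and the expectation rests on compound 2 alone. The change is expected to cost some activity, so the step of a number 13.3 percentage points lower from compound 2 to compound 3 (beyond the scatter) is estimated as a moderate decrease, beyond the usual scatter but leaving a clear effect. Compound 3 is expected to give about 40% in this assay, within a range from 15% to 65%.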

Compound 3, a percentage reported as activity, at one concentration (the size of the read-out at that concentration, not a potency): "not active" (no number reported)
The entry for compound 3 holds no number; the estimate stays without a comparison.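

In this assay, among these compounds, compound 2 gives 53.3%, while the entry for compound 3 carries no number, so no step between compound 2 and compound 3 can be read. Nothing shown bears on the reason for this result. The compounds shown leave open how large the effect of the oxygen-to-sulfur swap is on the shared core.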